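Piperidinyl in place of cyclopropyl on the pyrazole nitrogen

This account rests on a few compounds, and the source may have more. Where it says the series, first, only, none or still open, it means among the compounds named here.

Of the compounds shown here, three have been read in an assay on isolated protein for inhibition of Discoidin domain-containing receptor 2 (Homo sapiens), read by ELISA, with a stated time of 60 min; on this read-out higher numbers stand for weaker inhibition and lower numbers for stronger inhibition. Compound 1 `CCCn1cc(-c2n[nH]c3cc(-c4cc(C(=O)Nc5cccc(C(F)(F)F)c5)ccc4C)ccc23)cn1` gives 3.2 nM; compound 2 `Cc1ccc(C(=O)Nc2cccc(C(F)(F)F)c2)cc1-c1ccc2c(-c3cnn(C(C)C)c3)n[nH]c2c1` gives 7.7 nM; compound 3 `Cc1ccc(C(=O)Nc2cccc(C(F)(F)F)c2)cc1-c1ccc2c(-c3cnn(C4CC4)c3)n[nH]c2c1` gives 3.2 nM. Compound 3 thus stands level with compound 1, the two together at the lowest numbers of the three, with compound 2 furthest away at a 2.4-fold lower number from compound 2 to compound 3 (0.38 log units; beyond the scatter). The alkyl swaps so far are small: no change at the digits printed from compound 1 to compound 3 (within the scatter), while a 2.4-fold higher number from compound 1 to compound 2 (0.38 log units; beyond the scatter).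

Compound 4 `Cc1ccc(C(=O)Nc2cccc(C(F)(F)F)c2)cc1-c1ccc2c(-c3cnn(C4CCN(C)CC4)c3)n[nH]c2c1` differs from compound 3 by 1-methylpiperidin-4-yl in place of cyclopropyl on an aromatic nitrogen. Going by the values given here, no measured step exchanges a cyclopropyl for a ring of this kind on that nitrogen, so the three alkyl steps bear on it only as a guide to how tolerant that position has been. Given that the swaps between compound 1, compound 2 and compound 3 stayed modest, a change in the same range is expected in this assay for compound 4, in either direction or none beyond the scatter; the estimated step is a 1.6-fold higher number from compound 3 to compound 4 (0.19 log units; within the scatter). Compound 4 is thus expected to give about 5 nM, within 1.5 nM to 20 nM.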

Compound 4, half-maximal inhibitory concentration: 3.8 nM
The estimate for compound 4 lay 1.3-fold (0.12 log units) above the measured number; low and high end bracket the measured number.
By their numbers in this assay, from the lowest: compounds 1, 3 and 4 (each within the scatter of the next); then compound 2.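

In this assay, the aromatic nitrogen carries 1-methylpiperidin-4-yl, with 7 heavy atoms and a ring nitrogen, without leaving the range of the small carbon-only groups: the steps read a 1.2-fold higher number from compound 3 to compound 4 (0.07 log units; within the scatter) and a 1.2-fold higher number from compound 1 to compound 4 (0.07 log units; within the scatter). Against the isopropyl of compound 2 the same group gives a 2.0-fold lower number from compound 2 to compound 4 (0.31 log units; beyond the scatter), so heavy atom count does not order the numbers at this position across these four compounds, with compound 2 going against any such trend. Nothing available explains this tolerance.

Open, on these data alone, is whether the ring nitrogen contributes at all: cyclohexyl or tetrahydropyran-4-yl in the same place would separate it from ring size. Also open, as far as these compounds go, is how far the position tolerates other groups, such as a carboxylic acid or a longer chain ending in an amine.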